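Furan-2-yl in place of thiophen-2-yl on compound 1

The compounds below may be only part of what the source reports. "The series", "measured", "known", "first", "only" and "open" are said of these compounds alone.

Among the measured compounds shown here, in a physicochemical assay for solubility, measured as kinetic solubility (a higher number here means a more soluble compound, a lower number a less soluble compound), compound 1 (`O=C(Nc1ccc(Cl)cc1)C1CCCN(C(=O)c2cccc(-c3cccs3)c2)C1`) gives 1.36 ug/mL, the lower of the two numbers so far. Compound 2 (`O=C(Nc1ccc(Cl)cc1)C1CCCN(C(=O)c2cc(C(F)(F)F)cc(C(F)(F)F)c2)C1`) gives 4.5 ug/mL, a gap beyond the scatter. Compound 3 (`O=C(Nc1ccc(Cl)cc1)C1CCCN(C(=O)c2cccc(-c3ccco3)c2)C1`) carries furan-2-yl in place of thiophen-2-yl on an aromatic carbon, meta to a large group: furan-2-yl in place of thiophen-2-yl on an aromatic carbon. For the measured compounds named here, no measured pair isolates this change, so the expectation rests on compound 1 alone. The expected change is small and upward, not beyond the scatter: a 1.5-fold higher number from compound 1 to compound 3 (0.17 log units; within the scatter). In this assay, compound 3 is estimated at 2 ug/mL, with an expected range of 0.9 ug/mL to 5 ug/mL.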

Compound 3, solubility: 3.09 ug/mL
Compound 3: middle estimate off by 1.5-fold (0.19 log units), on the low side, within the range that was stated.
By their numbers in this assay, from the lowest: compound 1; then compounds 3 and 2 (each within the scatter of the next).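

Furan-2-yl in place of thiophen-2-yl on this aromatic carbon gives the first single-place comparison in the series: in this assay the step is a 2.3-fold higher number from compound 1 to compound 3 (0.36 log units; beyond the scatter). The exchange of sulfur for oxygen, with the heavy-atom count unchanged, is therefore enough to move the read-out beyond the scatter at this position. No measurement shown bears on the reason for this step.

Open, on these data alone, is how a six-membered ring such as pyridin-2-yl, or a basic amine such as a dimethylaminomethyl group, would read at this position. Also open, as far as these compounds go, is whether the same exchange gives a similar step elsewhere on the shared core.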